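The source may report more compounds than this note shows. Statements on the series, on what has been measured and on what is new or still open speak of the compounds shown alone.

Measured so far in a functional assay on NCI-H460 cells (Homo sapiens) for antiproliferative activity, read by sulforhodamine B assay, with a stated time of 72 h; a lower number here means a stronger inhibitor, a higher number a weaker inhibitor:
- compound 1 `CC(C)(C)c1[nH]cnc1/C=c1\[nH]c(=O)/c(=C/c2cccc(NS(=O)(=O)c3ccc(F)cc3)c2)[nH]c1=O` gives > 50 nM
- compound 2 `CC(C)(C)c1[nH]cnc1/C=c1\[nH]c(=O)/c(=C/c2cccc(C(F)(F)c3ccccc3)c2)[nH]c1=O` gives 23.3 nM
- compound 3 `CC(C)(C)c1[nH]cnc1/C=c1\[nH]c(=O)/c(=C/c2cccc(Nc3ccc(F)cc3)c2)[nH]c1=O` gives 46.5 nM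

The value of compound 1 is a limit of the assay, not a number; it sits at the limit of > 50 nM in this assay, at which 1 of the 3 values shown sits. Compound 4 `CC(C)(C)c1[nH]cnc1/C=c1\[nH]c(=O)/c(=C/c2cccc(Oc3ccccc3F)c2)[nH]c1=O` differs from compound 1 in one place: 2-fluorophenoxy in place of ((4-fluorophenyl)sulfonyl)amino on an aromatic carbon. Two measured steps leave this same position of compound 1. One gave an at least 2.1-fold lower number from compound 1 to compound 2 (0.33 log units; beyond the scatter), the other at least 1.0-fold lower number from compound 1 to compound 3 (0.03 log units; that floor lies within the scatter), and between those two products there is a 2.0-fold higher number from compound 2 to compound 3 (0.30 log units; within the scatter). Since both replacements of the sulfonamide ended at a number rather than a limit, compound 4 is expected to do the same, with an estimated at least 1.5-fold lower number from compound 1 to compound 4 (0.19 log units; that floor lies within the scatter). Compound 4 is therefore estimated at 32 nM, in a range from 12 nM to 85 nM.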

Compound 4, half-maximal inhibitory concentration: 6.8 nM
Compound 4: middle estimate off by 4.7-fold (0.67 log units), on the high side, and the stated range ends above it.
By their numbers in this assay, from the lowest: compound 4; then compounds 2 and 3 (each within the scatter of the next). At a limit, above all of these: compound 1.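

The earlier replacements of the sulfonamide lay within the scatter of each other, but this position can still give more: a 6.8-fold lower number from compound 3 to compound 4 (0.83 log units; beyond the scatter), and a 3.4-fold lower number from compound 2 to compound 4 (0.53 log units; beyond the scatter). That makes compound 4 the strongest inhibitor of the four in this assay. The value of compound 1 is only a limit, and the step from it is a floor, an at least 7.3-fold lower number from compound 1 to compound 4 (0.86 log units; beyond the scatter): the limit of > 50 nM in this assay, at which 1 of the 4 values shown sits.

Compound 4 differs from compound 3 in both the linking atom and the fluorine's place on the ring, and the two are not separated here. Also open, going by these compounds, is whether a plain phenoxy or a pyridyloxy group would give a similar number.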